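This account rests on a few compounds, and the source may have more. Where it says the series, first, only, none or still open, it means among the compounds named here.

Compound 1 `COc1ccc(-c2cncnc2-c2cc(OC)c(OC)c(OC)c2)cc1` gives 2850 nM
Compound 2 `COc1ccc(-c2cncnc2-c2cc(OC)c(OC)c(OC)c2)cc1O` gives 2750 nM
Compound 3 `CCOc1ccc(-c2cncnc2-c2cc(OC)c(OC)c(OC)c2)cc1` gives 640 nM

In a functional assay on SiHa cells (Homo sapiens) for antiproliferative activity, read by CCK-8 assay, with a stated time of 72 h (a lower number here means a stronger inhibitor, a higher number a weaker inhibitor), compound 3 has the lowest of the three numbers at 640 nM and its gaps to both others lie beyond the scatter. Compound 4 `COc1cc(-c2ncncc2-c2ccc(C(N)=O)cc2)cc(OC)c1OC` carries carbamoyl in place of ethoxy on an aromatic carbon, para to a large group (carbamoyl in place of ethoxy on an aromatic carbon). Among the measured compounds shown here, no measured compound carries carbamoyl, which leaves the size of this step poorly defined. The closest evidence is a 4.5-fold lower number from compound 1 to compound 3 (0.65 log units; beyond the scatter) at the same group, together with a 4.3-fold lower number from compound 2 to compound 3 (0.63 log units; beyond the scatter) for the swap to 4-ethoxyphenyl. By contrast, a 1.0-fold lower number from compound 1 to compound 2 (0.02 log units; within the scatter) adds little. Both modest steps end at compound 3, and loss of ethoxy is expected to give back at least that much, with a higher number in this assay beyond the scatter. The expected change is a 4.7-fold higher number from compound 3 to compound 4 (0.67 log units; beyond the scatter) as a rough estimate. Compound 4 is estimated at 3000 nM with a wide expected range (700 nM to 12000 nM).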

Compound 4, half-maximal inhibitory concentration: > 100000 nM
Compound 4: only a limit was reported; the forecaster's own chance of this, stated with the estimate: 10%; middle value at least 33-fold (1.52 log units) away from the limit.
By their numbers in this assay, from the lowest: compound 3; then compounds 2 and 1 (each within the scatter of the next). At a limit, above all of these: compound 4.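

In this assay compound 4 gives only a limit of the assay, not a number: the limit of > 100000 nM in this assay, at which 1 of the 4 values shown sits. The earlier changes at this position moved the number modestly at most, whereas carbamoyl in place of an ether gives an at least 150-fold higher number from compound 3 to compound 4 (2.19 log units; beyond the scatter), with an at least 35-fold higher number from compound 1 to compound 4 (1.54 log units; beyond the scatter) and an at least 36-fold higher number from compound 2 to compound 4 (1.56 log units; beyond the scatter) on the same scale. Ethoxy and carbamoyl match in heavy atoms, so the heavy-atom count of the group alone does not set the activity at this position, and the position is far less permissive than the first three compounds suggested.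

The compounds shown leave open whether the loss is particular to carbamoyl or extends to groups such as a nitrile, a carboxylic acid or an amine. They also leave open whether the gain from methoxy to ethoxy continues with a longer chain such as propoxy.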